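Swapping Amino for Carbamoyl in Compound 1

The source may hold more compounds than are shown below. What is called first, only, known or untested is meant among the compounds shown, and "the series" means these compounds.

Measured in a functional assay on SK-MEL-28 cells (Homo sapiens) for cytotoxicity, read by MTT assay, with a stated time of 3 days; a lower number here means a stronger inhibitor, a higher number a weaker inhibitor:
- Compound 1 `N#Cc1c(NN)nc(SCc2nc3ccccc3[nH]2)nc1-c1ccccc1`: 3 nM
- Compound 2 `N#Cc1c(NC(N)=S)nc(SCc2nc3ccccc3[nH]2)nc1-c1ccccc1`: 4.8 nM

For the measured compounds named here, compound 1 stands level with compound 2, the only other measured compound, as the two values lie within the scatter of each other. Compound 3 `N#Cc1c(NC(N)=O)nc(SCc2nc3ccccc3[nH]2)nc1-c1ccccc1` differs from compound 1 by carbamoyl in place of amino on a nitrogen on an aromatic ring. Going by the values given here, one measured step bears on this, a 1.6-fold higher number from compound 1 to compound 2 (0.20 log units; within the scatter), which also replaces amino at this place, with a group holding sulfur where carbamoyl holds oxygen. One step is thin evidence, but it points to no change beyond the scatter in this assay. The estimated step is a 1.7-fold higher number from compound 1 to compound 3 (0.22 log units; within the scatter). For compound 3 the expected value is 5 nM, within an estimated range of 2 nM to 15 nM.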

Compound 3, half-maximal inhibitory concentration: 4.8 nM
Compound 3: middle estimate off by 1.0-fold (0.02 log units), on the high side, within the range that was stated.
By their numbers in this assay, from the lowest: compounds 1, 2 and 3 (each within the scatter of the next).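

In this assay carbamoyl in place of amino on a nitrogen on an aromatic ring gives a 1.6-fold higher number from compound 1 to compound 3 (0.20 log units; within the scatter) and so reads the same as the sulfur-bearing group at this place. Exchanging that group for carbamoyl gives no change at the digits printed from compound 2 to compound 3 (within the scatter) so sulfur and oxygen cannot be told apart here. Nothing measured explains why these groups read alike.

As far as these compounds go, it remains open whether an acetyl group, a carboxylic acid or a longer chain such as butyl would also stay within the scatter at this place. From the compounds shown here alone, whether a methylamine would do so is equally open.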